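This account rests on a few compounds, and the source may have more. Where it says the series, first, only, none or still open, it means among the compounds named here.

Measured so far:
compound 1 `CC(C)(C)c1cc(NC(=O)[C@@H]2CCCCN2C2CC2)no1` — 38 ug/mL
compound 2 `CC(C)(C)c1cc(NC(=O)[C@@H]2CCCCN2CC2CCOCC2)no1` — 72 ug/mL

In a physicochemical assay for solubility, read by HPLC, at pH 6.8 (a lower number here means a less soluble compound, a higher number a more soluble compound), compound 2 gives the higher of the two numbers, but the step of a 1.9-fold higher number from compound 1 to compound 2 (0.28 log units; within the scatter) lies within the scatter. Compound 3 `CC(C)(C)c1cc(NC(=O)[C@@H]2CCCCN2C(=O)c2ccc(Cl)cc2)no1` differs from compound 2 by (4-chlorophenyl)carbonyl in place of (oxan-4-yl)methyl on an amine nitrogen in a ring. Among the measured compounds shown here, no measured step covers a carbonyl entering at this nitrogen; the only measured step at that place is a 1.9-fold higher number from compound 1 to compound 2 (0.28 log units; within the scatter), and it is within the scatter, so it gives little guidance. Compound 3 is nonetheless expected to give a lower number, a step of a 4.8-fold lower number from compound 2 to compound 3 (0.68 log units; beyond the scatter). For compound 3 the estimate is 15 ug/mL, with a range from 4 ug/mL to 60 ug/mL.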

Compound 3, solubility: < 0.1 ug/mL
Compound 3: no number, only a limit; the forecaster's own chance of this, stated with the estimate: 10%; middle value at least 150-fold (2.17 log units) from the limit.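

Among the compounds shown here, on an amine nitrogen in a ring, the one earlier exchange stayed within the scatter, but (4-chlorophenyl)carbonyl brings a large step from either earlier group in this assay: an at least 720-fold lower number from compound 2 to compound 3 (2.85 log units; beyond the scatter), and an at least 380-fold lower number from compound 1 to compound 3 (2.57 log units; beyond the scatter). So this position does not tolerate every change equally in this read-out. For compound 3 the reading is a limit, not a number: the limit of < 0.1 ug/mL in this assay, at which 1 of the 3 values shown sits.

The compounds shown do not separate the carbonyl from the aromatic ring, as both enter together. Going by these compounds, how an acetyl group or a 4-chlorobenzyl group would read on this nitrogen stays open.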